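Capping a Hydroxyl: Methoxymethyl in Place of Hydrogen

This account rests on a few compounds, and the source may have more. Where it says the series, first, only, none or still open, it means among the compounds named here.

Compound 1 `C/C1=C\[C@@H](O)C(=O)/C=C/C=C/c2csc(n2)[C@@H](C)N2C(=O)C[C@@]([C@@](C)(O)C(=O)SCc3oc(=O)oc3C)(CC1)[S+]2[O-]` in an ADME assay for pharmacokinetics, read by HPLC (a higher number here means that the compound lasts longer, a lower number that the compound disappears faster), gives 16 h. Compound 2 `C/C1=C\[C@@H](O[C@H]2CCCCO2)C(=O)/C=C/C=C/c2csc(n2)[C@@H](C)N2C(=O)C[C@@]([C@@](C)(O)C(=O)SCc3oc(=O)oc3C)(CC1)[S+]2[O-]` in this assay gives 30 h, and the step of a 1.9-fold higher number from compound 1 to compound 2 (0.27 log units; within the scatter) means the two numbers cannot be told apart. Compound 3 `COCO[C@@H]1/C=C(\C)CC[C@]2([C@@](C)(O)C(=O)SCc3oc(=O)oc3C)CC(=O)N([C@H](C)c3nc(cs3)/C=C/C=C/C1=O)[S+]2[O-]` differs from compound 1 in one place: methoxymethyl in place of hydrogen on an oxygen on a saturated carbon. Among the measured compounds shown here, only that one measured step, a different group entering at the same kind of oxygen, bears on this change, and it stayed within the scatter, so for compound 3 a step of a 1.4-fold higher number from compound 1 to compound 3 (0.14 log units; within the scatter) is expected, with nothing beyond the scatter. Compound 3 is therefore estimated at 22 h, within 12 h to 40 h.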

Compound 3, half-life: 24 h
Compound 3: middle estimate off by 1.1-fold (0.04 log units), on the low side, and the stated range covers the measured number.
By their numbers in this assay, from the lowest: compounds 1, 3 and 2 (each within the scatter of the next).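

With methoxymethyl on this oxygen, a second cap joins oxan-2-yl, and in this assay it also stays within the scatter of the free hydroxy (a 1.5-fold higher number from compound 1 to compound 3 (0.18 log units; within the scatter)). The two capped compounds cannot be told apart either (a 1.3-fold lower number from compound 2 to compound 3 (0.10 log units; within the scatter)), so neither swap at this position shows a real change in how long the compound lasts. No measurement shown here offers an explanation for these numbers. Still open, from the compounds shown here alone, is whether an amine, a carboxylic acid or a longer chain at this oxygen would move the number beyond the scatter.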